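The source may hold more compounds than are shown below. What is called first, only, known or untested is meant among the compounds shown, and "the series" means these compounds.

Compounds in this series share the core and the ((3,5-dichlorobenzyl)oxy)carbonyl group, and the first three differ on the saturated chain carbon bound to an aromatic carbon. In a functional assay on A549 cells (Homo sapiens) for inhibition, read by MTT assay, with a stated time of 72 h (a higher number here means a weaker inhibitor, a lower number a stronger inhibitor), compound 1 `CCc1nc2c(C)cc(-c3ccc(CN4CCC[C@H]4CO)cc3)cn2c1NC(=O)OCc1cc(Cl)cc(Cl)c1` gives 5780 nM, and compound 2 `CCc1nc2c(C)cc(-c3ccc(CN4CCN(C)CC4)cc3)cn2c1NC(=O)OCc1cc(Cl)cc(Cl)c1` gives 4020 nM. These two sit within the scatter of each other: a 1.4-fold lower number from compound 1 to compound 2 (0.16 log units; within the scatter). Compound 3 `CCc1nc2c(C)cc(-c3ccc(CNCCO)cc3)cn2c1NC(=O)OCc1cc(Cl)cc(Cl)c1` reads > 20000 nM, which is a limit and not a number. The steps to it are an at least 3.4-fold higher number from compound 1 to compound 3 (0.53 log units; beyond the scatter) and an at least 4.9-fold higher number from compound 2 to compound 3 (0.69 log units; beyond the scatter).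

Compound 4 `CCc1nc2c(C)cc(-c3ccc(CN4CCN(C)CC4)cc3)cn2c1NC(=O)OCc1ccc(F)c(F)c1` keeps the 4-methylpiperazin-1-yl group of compound 2 and changes the other end: 3,4-difluorophenyl in place of 3,5-dichlorophenyl on a saturated chain carbon bound to an oxygen next to a carbonyl group. This puts 3,4-difluorophenyl in place of 3,5-dichlorophenyl on a saturated chain carbon bound to an oxygen next to a carbonyl group. For the measured compounds named here, no measured step touches this place, so the steps above give neither size nor direction for it. No shift beyond the scatter is therefore expected in this assay, though with wide uncertainty. The expected step is a 1.2-fold higher number from compound 2 to compound 4 (0.09 log units; within the scatter). For compound 4 the estimated value is 5000 nM, with an expected range of 1800 nM to 15000 nM.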

Compound 4, half-maximal inhibitory concentration: > 20000 nM
Compound 4 was reported as a limit; the forecaster's own chance of this, stated with the estimate: 12%; at least 4.0-fold (0.60 log units) between middle value and limit.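

In this assay, for the compounds shown here, the earlier compounds varied only the group on the saturated chain carbon bound to an aromatic carbon, so this is the first reading at the other end of the molecule, and there 3,4-difluorophenyl in place of 3,5-dichlorophenyl is not a neutral exchange: an at least 4.9-fold higher number from compound 2 to compound 4 (0.69 log units; beyond the scatter). Compound 4 reads > 20000 nM, which is a limit of the assay and not a number. The step therefore fixes a direction and a minimum size, with its full size unread: the limit of > 20000 nM in this assay, at which 2 of the 4 values shown sit.

The compounds shown do not separate the exchange of chlorine for fluorine from the change in ring pattern; 3,4-dichlorophenyl or 3,5-difluorophenyl on the same carbon would do so. Also open, from the compounds shown here alone, is whether the step holds with the 2-(hydroxymethyl)pyrrolidin-1-yl group of compound 1 in place of the 4-methylpiperazin-1-yl group.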